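This account rests on a few compounds, and the source may have more. Where it says the series, first, only, none or still open, it means among the compounds named here.

Working notes on the series. Of the compounds shown here, two have numbers so far in a functional assay on Bel-7402 cells (Homo sapiens) for inhibition, read by sulforhodamine B assay, with a stated time of 72 h, tested at 10 uM; on this read-out higher numbers stand for more inhibition at the one concentration tested (going by the name of the read-out) and lower numbers for less inhibition. Compound 1 `C[C@H](Nc1nc(N)nc(N)c1C#N)c1nn(-c2cccc(S(C)(=O)=O)c2)c2cc(F)ccc12` gives 14% in this assay . Compound 2 `Cc1ccc2c(c1)c([C@H](C)Nc1ncnc3[nH]cnc13)nn2-c1cccnc1` gives -10% in this assay . Compound 1 stands highest of the two numbers; the nearest is compound 2, lower by a gap that falls beyond the scatter. Within the data shown here, no pair differing in one place has both numbers yet, so no step size is known from measurement.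

Compound 3 `C[C@H](Nc1nc(N)nc(N)c1C#N)c1nn(-c2cccc(S(C)(=O)=O)c2)c2cc(Cl)ccc12` is not yet measured. It differs from compound 1 by chloro in place of fluoro on an aromatic carbon. For a change of this kind the expectation for this assay is a step of small size, if anything slightly upward, most likely within the scatter; the expected step is a number 4 percentage points higher from compound 1 to compound 3 (within the scatter). On that basis compound 3 is estimated to give 18% in this assay , with a range from 2% to 36%.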

Compound 3, a percentage reported as inhibition, at one concentration (the size of the read-out at that concentration, not a potency): 47%
Compound 3: middle estimate off by 29 percentage points, on the low side, outside the stated range (above it).
By their numbers in this assay, from the lowest: compound 2; then compound 1; then compound 3.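

In this assay, chloro in place of fluoro on this aromatic carbon, meta to a fused ring and para to a fused ring, gives a number 33 percentage points higher from compound 1 to compound 3 (beyond the scatter). Among these compounds, this is the first step measured, and it shows that a swap of one heavy atom at this position, with no change in ring, hydrogen-bond donor or acceptor counts or net charge, can move the read-out well beyond the scatter. Nothing at hand accounts for the size of this step.

As far as these compounds go, whether the trend continues with bromo, or reverses with hydrogen, methyl, methoxy or an amine on the same carbon, stays open. This single pair also leaves open whether the same exchange would give a step of similar size on another core, or in any other assay.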